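Sulfone-linked series: one fluoro removed from compound 1

This account rests on a few compounds, and the source may have more. Where it says the series, first, only, none or still open, it means among the compounds named here.

Three compounds of the series carry a measurement in an assay on isolated protein for displacement of a labelled ligand from metabotropic glutamate receptor 5 (Homo sapiens), with a stated time of 60 min, tested at 1 uM; on this read-out higher numbers stand for more inhibition at the one concentration tested (going by the name of the read-out) and lower numbers for less inhibition. Compound 1 `CC1CCN(c2c(S(=O)(=O)c3cc(F)cc(F)c3)cnc3c(F)cccc23)CC1` gives 9%, compound 2 `CC1CCN(c2c(S(=O)(=O)c3ccc(C#N)cc3)cnc3cc(Cl)ccc23)CC1` gives 70% and compound 3 `Cc1ccc(S(=O)(=O)c2cnc3ccc(Cl)cc3c2N2CCC(C)CC2)cc1` gives 95%. Compound 1 stands lowest of the three; the nearest number, that of compound 2, is higher by a margin beyond the scatter, and the furthest, that of compound 3, is higher by a margin beyond the scatter as well. Compounds 2 and 3 differ from compound 1 in more than one place, so neither gap can be read as the effect of a single change.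

Compound 4 `CC1CCN(c2c(S(=O)(=O)c3cccc(F)c3)cnc3c(F)cccc23)CC1` has not been measured. It differs from compound 1 in one place only: hydrogen in place of fluoro on an aromatic carbon. The same difference, cut one bond further out, reads 3,5-difluorophenyl to 3-fluorophenyl. Among the compounds with values here, no pair of measured compounds shows this step, so nothing in the numbers fixes its size or direction. With a single fluoro removed and nothing else moved, only a small step is expected in this assay, in either direction or none beyond the scatter, and the step of a number 3 percentage points higher from compound 1 to compound 4 (within the scatter) expected here is within the scatter. Compound 4 is accordingly estimated at 12%, with a range from 0% to 35%.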

Compound 4, a percentage reported as inhibition, at one concentration (the size of the read-out at that concentration, not a potency): 62%
The estimate for compound 4 lay 50 percentage points below the measured number; the whole stated range lies below it.
By their numbers in this assay, from the lowest: compound 1; then compounds 4 and 2 (each within the scatter of the next); then compound 3.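

In this assay, within the data shown here, hydrogen in place of fluoro on this aromatic carbon gives a number 53 percentage points higher from compound 1 to compound 4 (beyond the scatter), the first step that can be read as a single change, and it marks this position as one where the read-out responds strongly. Compounds 2 and 3 differ from compound 1 in more than one place, so they could not tie the low number of compound 1 to any one feature, whereas this step links much of the gap to the second fluoro of the 3,5-difluorophenyl group, with the rest of compound 1 unchanged. Nothing measured in this set bears on the reason for a step of this size.

Open, as far as these compounds go, is what the remaining fluoro of the 3-fluorophenyl group contributes, and whether a methoxy group or an amine on the same aromatic carbon would keep the number of compound 4 or lose it. Also open, from the compounds shown here alone, is whether the same step holds on a core carrying the chloro of compounds 2 and 3 rather than the fluoro of the core of compound 1.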